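A few compounds are considered here, and "the series" means these few. Any claim that something is new, unique, unknown or untested is made for them only; others in the source may bear on it.

Among the compounds with values here, in a functional assay on NUGC-3 cells (Homo sapiens) for cytotoxicity, read by sulforhodamine B assay, with a stated time of 72 h (a lower number here means a stronger inhibitor of growth, a higher number a weaker inhibitor of growth), compound 2 `O=C(Nc1ccccc1O)C1CCc2ccccc2N1` gives 2680 nM, the only numerical value in the set. Compound 1 `O=C(Nc1ccc(O)cc1)C1CCc2ccccc2N1` yields in this assay only a limit, > 100000 nM. Compound 2 thus stands alone with a measured number, the other entry being a limit (the limit of > 100000 nM in this assay, at which 1 of the 2 values shown sits). Compound 3 `O=C(Nc1ccccc1)C1CCc2ccccc2N1` differs from compound 2 by hydrogen in place of hydroxy on an aromatic carbon. Within the data shown here, no measured pair shows such a removal, so a moderate weakening beyond the scatter is expected in this assay. The estimate for compound 3 is 8000 nM, between 1500 nM and 50000 nM. The expected step is a 3.0-fold higher number from compound 2 to compound 3 (0.47 log units; beyond the scatter).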

Compound 3, concentration for 50% growth inhibition: 59000 nM
Beside the measured number, compound 3's estimate is 7.4-fold (0.87 log units) below it; measured number outside the range, above it.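

Hydrogen in place of hydroxy on an aromatic carbon, ortho to a large group, gives in this assay a 22-fold higher number from compound 2 to compound 3 (1.34 log units; beyond the scatter), so growth inhibition in this pair depends strongly on that hydroxy. The same kind of replacement gives an at least 1.6-fold lower number from compound 1 to compound 3 (0.22 log units; that floor lies within the scatter), which does not separate these two compounds. Compound 1 stands at a limit, not a number: the limit of > 100000 nM in this assay, at which 1 of the 3 values shown sits.

From the compounds shown here alone, whether a methoxy group, an amine or a fluorine at this place retains the potency of compound 2 remains open.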